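Swapping a hydroxypyrrolidine for a dimethylamine

The source may hold more compounds than are shown below. What is called first, only, known or untested is meant among the compounds shown, and "the series" means these compounds.

Measured so far:
- Compound 1 `CC(C)N(CCN(C(=O)Nc1ccc(F)c(Cl)c1)C1CC[C@]2(c3cccc(C#N)c3)CC2C1)C(C)C` gives 4.98 nM in a functional assay for antagonist activity at melanin-concentrating hormone receptor 1 (Homo sapiens); on this read-out lower numbers stand for stronger inhibition and higher numbers for weaker inhibition.
- Compound 2 `CC(=O)NCc1cccc([C@]23CCC(N(CCN(C(C)C)C(C)C)C(=O)Nc4ccc(F)c(Cl)c4)CC2C3)c1` gives 31 nM in this assay.
- Compound 3 `CC(C)N(CCN(C(=O)Nc1ccc(F)c(Cl)c1)C1CC[C@]2(c3cccc(CN4CC[C@H](O)C4)c3)CC2C1)C(C)C` gives 21 nM in this assay.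

Compound 3 stands second highest of the three numbers; its nearest neighbour is compound 2, since a 1.5-fold lower number from compound 2 to compound 3 (0.17 log units; within the scatter), while the furthest is compound 1, since a 4.2-fold higher number from compound 1 to compound 3 (0.62 log units; beyond the scatter). Compound 4 `CC(C)N(CCN(C(=O)Nc1ccc(F)c(Cl)c1)C1CC[C@]2(c3cccc(CN(C)C)c3)CC2C1)C(C)C` has not yet been measured. It differs from compound 3 in one place: dimethylamino in place of 3-hydroxypyrrolidin-1-yl on a saturated chain carbon bound to an aromatic carbon.

Within the data shown here, no measured step tests this exact swap. What bears on it is that the two benzylic substituents already seen behave alike, as a 1.5-fold lower number from compound 2 to compound 3 (0.17 log units; within the scatter) shows, and that both sit modestly above compound 1, as a 6.2-fold higher number from compound 1 to compound 2 (0.79 log units; beyond the scatter) and a 4.2-fold higher number from compound 1 to compound 3 (0.62 log units; beyond the scatter) show. A third basic or polar group on that chain carbon is therefore expected to land close to compound 3, with no step beyond the scatter: a 1.3-fold lower number from compound 3 to compound 4 (0.12 log units; within the scatter). Compound 4 is estimated at 16 nM, with a likely range from 6 nM to 45 nM.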

Compound 4, inhibition constant: 13 nM
Estimate against measurement, compound 4: 1.2-fold (0.09 log units) above; low and high end bracket the measured number.
By their numbers in this assay, from the lowest: compound 1; then compounds 4, 3 and 2 (each within the scatter of the next, the first and the last beyond it).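

In this assay the 3-hydroxypyrrolidin-1-yl group can give way to dimethylamino, which gives up its ring, its hydrogen-bond donor and its defined stereocentre, and the result stays within the scatter: a 1.6-fold lower number from compound 3 to compound 4 (0.21 log units; within the scatter). At this saturated chain carbon, then, neither the ring nor the donor is needed to keep the number at the level of compound 3. Dimethylamino is also the first replacement here to separate clearly from acetamido, a 2.4-fold lower number from compound 2 to compound 4 (0.38 log units; beyond the scatter), yet the nitrile remains ahead of it, a 2.6-fold higher number from compound 1 to compound 4 (0.42 log units; beyond the scatter).

Nothing given here explains these differences. Going by these compounds, it remains open whether a primary amine, a morpholine or a carboxylic acid on the same chain carbon would come closer to compound 1 or fall back towards compound 2.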